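A few compounds are considered here, and "the series" means these few. Any claim that something is new, unique, unknown or untested is made for them only; others in the source may bear on it.

Among the compounds with values here, compound 1 `CC/C(=C(/c1ccc(/C=C/C(=O)O)cc1)c1cc2ccccc2[nH]1)c1ccccc1OC(F)(F)F` gives 206 nM in a functional assay on MCF7 cells (Homo sapiens) for inhibition (on this read-out lower numbers stand for stronger inhibition and higher numbers for weaker inhibition), the second highest of the three numbers measured so far. Compound 2 `CC/C(=C(/c1ccc(/C=C/C(=O)O)cc1)c1cc2ccccc2[nH]1)c1cc(Cl)ccc1Cl` gives 71 nM, and compound 3 `CC/C(=C(/c1ccc(/C=C/C(=O)O)cc1)c1cc2ccccc2[nH]1)c1ccc(Cl)c(C)c1` gives 840 nM. Compound 4 `CC/C(=C(/c1ccc(/C=C/C(=O)O)cc1)c1cc2ccccc2[nH]1)c1ccc(Cl)c(C(F)(F)F)c1` has not yet been measured; its change from compound 1 is 4-chloro-3-(trifluoromethyl)phenyl in place of 2-(trifluoromethoxy)phenyl on a double-bonded chain carbon bound to a double-bonded chain carbon and a saturated chain carbon. Within the data shown here, two measured steps bear on this change: a 2.9-fold lower number from compound 1 to compound 2 (0.46 log units; beyond the scatter) and a 4.1-fold higher number from compound 1 to compound 3 (0.61 log units; beyond the scatter). The new group in compound 4 resembles the 4-chloro-3-methylphenyl of compound 3, the weakest of the three, more than the groups of compound 1 or compound 2, and a 12-fold higher number from compound 2 to compound 3 (1.07 log units; beyond the scatter) shows how far such a group can move the number. Compound 4 is therefore expected to land near that weaker level, an expected step of a 3.4-fold higher number from compound 1 to compound 4 (0.53 log units; beyond the scatter). The estimate for compound 4 is 700 nM, with a range from 250 nM to 2000 nM.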

Compound 4, half-maximal inhibitory concentration: 2200 nM
Estimate against measurement, compound 4: 3.1-fold (0.50 log units) below, outside the stated range (above it).
By their numbers in this assay, from the lowest: compound 2; then compound 1; then compound 3; then compound 4.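

Trifluoromethyl in place of methyl on an aromatic carbon gives a 2.6-fold higher number from compound 3 to compound 4 (0.42 log units; beyond the scatter), so even this single change within the group moves the number beyond the scatter. The 4-chloro-3-(trifluoromethyl)phenyl group gives the highest number of the four, with an 11-fold higher number from compound 1 to compound 4 (1.03 log units; beyond the scatter) and a 31-fold higher number from compound 2 to compound 4 (1.49 log units; beyond the scatter), which widens the span seen at this position. Nothing measured here explains these differences. Going by these compounds, whether a methoxy group or a nitrile on that aromatic carbon would give a lower number stays open, as does how a plain phenyl would compare.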